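A few compounds are considered here, and "the series" means these few. Any claim that something is new, unique, unknown or untested is made for them only; others in the source may bear on it.

Compound 2 `CN1CCN(CCCCOc2c(OCc3ccc(C#N)cc3)cc(O)c3c(=O)cc(-c4ccccc4)oc23)CC1` gives 3700 nM in a functional assay on B16 cells (Mus musculus) for cytotoxicity, read by MTT assay, with a stated time of 72 h (a lower number here means a stronger inhibitor, a higher number a weaker inhibitor), a number within the scatter of that of compound 1 `Cc1ccc(COc2cc(O)c3c(=O)cc(-c4ccccc4)oc3c2OCCCCN2CCN(C)CC2)cc1`, which gives 3290 nM; the step of a 1.1-fold higher number from compound 1 to compound 2 (0.05 log units; within the scatter) is small. Compound 3 `CN1CCN(CCCCOc2c(OCc3ccco3)cc(O)c3c(=O)cc(-c4ccccc4)oc23)CC1` differs from compound 2 by furan-2-yl in place of 4-cyanophenyl on a saturated chain carbon bound to an oxygen on an aromatic ring. Among the measured compounds shown here, the only measured step at this same saturated chain carbon is the one from compound 1 to compound 2, and it stayed within the scatter, so compound 3 is expected to shift in this assay by no more than a 1.2-fold higher number from compound 2 to compound 3 (0.09 log units; within the scatter), if anything toward a weaker inhibitor. Compound 3 is therefore estimated at 4500 nM, with a range from 2500 nM to 8500 nM.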

Compound 3, half-maximal inhibitory concentration: 3530 nM
Compound 3: middle estimate off by 1.3-fold (0.11 log units), on the high side; low and high end bracket the measured number.
By their numbers in this assay, from the lowest: compounds 1, 3 and 2 (each within the scatter of the next).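

In this assay, the steps of a 1.0-fold lower number from compound 2 to compound 3 (0.02 log units; within the scatter) and a 1.1-fold higher number from compound 1 to compound 3 (0.03 log units; within the scatter) both lie within the scatter. Among the compounds shown here, the earlier compounds had compared only two substituted phenyl groups at this saturated chain carbon bound to an oxygen on an aromatic ring, whereas furan-2-yl brings a five-membered aromatic ring with 1 hetero atom and 5 heavy atoms and still gives a number within the scatter of both. Nothing at hand offers an explanation for this result. Going by these compounds, what stays open is whether a group with no aromatic ring at this carbon, such as a cyclohexyl group, a primary amine or a carboxylic acid, would also stay within the scatter.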